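A Cyano Swap at the Limit of the Assay

This account rests on a few compounds, and the source may have more. Where it says the series, first, only, none or still open, it means among the compounds named here.

Of the compounds shown here, three have been tested in a functional assay on MT4 cells (Homo sapiens) for cytotoxicity (a lower number here means a stronger inhibitor, a higher number a weaker inhibitor), and none has yet given an exact number. Compound 1 `N#Cc1ccc(Sc2cccc(N)c2C#N)cc1` reads > 200000 nM as a limit of the test and not as a number. Compound 2 `COc1ccc(S(=O)(=O)c2cccc(N)c2C#N)cc1` reads > 200000 nM as a limit too. Compound 3 `Cc1ccccc1S(=O)(=O)c1cccc(N)c1C#N` reads > 200000 nM as a limit as well. Compound 2 therefore has no measured rank among the three, since all of them share one reading the limit of > 200000 nM in this assay, at which 3 of the 3 values shown sit, and cannot be placed in order.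

The next compound to be measured is compound 4 `N#Cc1ccc(S(=O)(=O)c2cccc(N)c2C#N)cc1`, which has cyano in place of methoxy on an aromatic carbon, para to a large group (cyano in place of methoxy on an aromatic carbon). Going by the values given here, no step between measured compounds offers a direct guide to this change. Compound 1 also carries a cyano group, and its reading of > 200000 nM is again only a limit. In this assay, no change beyond the usual scatter is expected, so the estimated step of a number no higher from compound 2 to compound 4 (the limit leaves the size open) is a small one. For compound 4 the expected value is 200000 nM with an estimated range of 80000 nM to 400000 nM and a good chance of another limit.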

Compound 4, half-maximal inhibitory concentration: > 200000 nM
Compound 4: no number, only a limit (the forecaster's own chance of this, stated with the estimate: 80%); the middle value sits exactly at the limit.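

Cyano in place of methoxy gives no step that can be read between compound 2 and compound 4, because both readings stop at one limit and neither is a number: the limit of > 200000 nM in this assay, at which 4 of the 4 values shown sit.

The compounds shown leave open how these four would rank in this assay, and whether any change to the shared core would give an exact number there.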